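Swapping an Anilino Group for a Piperidine on the Core

The source may hold more compounds than are shown below. What is called first, only, known or untested is meant among the compounds shown, and "the series" means these compounds.

Measured so far:
compound 1, `Nc1ccccc1NC(=O)/C=C/c1ccc(Cn2cnc3c(Nc4cccc(Cl)c4)nc(Cl)nc32)cc1`: 49.3%
compound 2, `Nc1ccccc1NC(=O)c1ccc(COCNc2nc(Nc3ccccc3)c3ncn(C4CCCC4)c3n2)cc1`: 66.9%

Both numbers come from a functional assay on HepG2 cells (Homo sapiens) for antiproliferative activity, read by CCK-8 assay, with a stated time of 72 h, tested at 8 uM; on this read-out higher numbers stand for a stronger effect at the one concentration tested and lower numbers for a weaker effect. Compound 1 stands lowest of the two; compound 2 sits beyond the usual scatter above it. Compound 3, `CC1CCN(c2nc(Cl)nc3c2ncn3Cc2ccc(/C=C/C(=O)Nc3ccccc3N)cc2)CC1`, has not been measured. It differs from compound 1 in one place: 4-methylpiperidin-1-yl in place of (3-chlorophenyl)amino on an aromatic carbon. Among the measured compounds shown here, no measured pair shows this kind of change, so no step is known for it. Because compound 1 gives 49.3%, compound 3 is estimated at 45%, between 25% and 68%. The expected step of a number 4.3 percentage points lower from compound 1 to compound 3 (within the scatter) is not beyond the scatter.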

Compound 3, a percentage reported as inhibition, at one concentration (the size of the read-out at that concentration, not a potency): 32.2%
Beside the measured number, compound 3's estimate is 12.8 percentage points above it, within the range that was stated.
By their numbers in this assay, from the lowest: compound 3; then compound 1; then compound 2.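

In this assay, placing 4-methylpiperidin-1-yl on this aromatic carbon in place of (3-chlorophenyl)amino gives a number 17.1 percentage points lower from compound 1 to compound 3 (beyond the scatter) and so shows that the group here affects the read-out. The change removes the aromatic ring and the hydrogen-bond donor together, and this single step cannot separate the two. Nothing measured here explains the drop. From the compounds shown here alone, it remains open whether the ring or the donor matters more. A cyclohexylamino group, with its non-aromatic ring and its hydrogen on nitrogen, would help to separate them.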